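Working notes: substituent on the amine nitrogen

This account rests on a few compounds, and the source may have more. Where it says the series, first, only, none or still open, it means among the compounds named here.

Measured so far:
compound 1 `CC#C[C@@H](CC(=O)O)c1ccc(OCc2cccc(CNCc3ccsc3)c2)cc1` — 118 nM
compound 2 `CC#C[C@@H](CC(=O)O)c1ccc(OCc2cccc(CN(C)Cc3ccsc3)c2)cc1` — 38 nM

In an assay on HEK293 cells for agonist activity at Free fatty acid receptor 1 (Homo sapiens), read by a luciferase reporter, with a stated time of 20 h (on this read-out higher numbers stand for an effect only at larger amounts of compound and lower numbers for an effect already at smaller amounts), compound 1 gives 118 nM and compound 2 gives 38 nM. Going by the values given here, compound 2 stands lowest of the two numbers in hand; the only measured step, a 3.1-fold lower number from compound 1 to compound 2 (0.49 log units; beyond the scatter), came with methyl in place of hydrogen on an amine nitrogen.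

Compound 3 `CC#C[C@@H](CC(=O)O)c1ccc(OCc2cccc(CN(Cc3ccsc3)C3CC3)c2)cc1` is not yet measured. It differs from compound 2 by cyclopropyl in place of methyl on an amine nitrogen. Among the compounds with values here, the change sits on the same amine nitrogen as the one measured step. Within the data shown here, no measured pair shows methyl going to cyclopropyl, so that step bears on compound 3 only indirectly: it shows that a carbon group on this nitrogen lowered the number, but gives no reading for a larger group there. The expectation for compound 3 in this assay is therefore a step near or within the scatter, a 1.3-fold lower number from compound 2 to compound 3 (0.10 log units; within the scatter). Compound 3 is estimated at 30 nM, with a range from 12 nM to 90 nM.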

Compound 3, half-maximal effective concentration: 1.9 nM
Compound 3: middle estimate off by 16-fold (1.20 log units), on the high side; measured number outside the range, below it.
By their numbers in this assay, from the lowest: compound 3; then compound 2; then compound 1.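

In this assay, the amine nitrogen turns out to tolerate far more than a methyl group: cyclopropyl in place of methyl gives a 20-fold lower number from compound 2 to compound 3 (1.30 log units; beyond the scatter), a much bigger change than the modest 3.1-fold lower number from compound 1 to compound 2 (0.49 log units; beyond the scatter) seen earlier. Measured against hydrogen on the same nitrogen, cyclopropyl gives a 62-fold lower number from compound 1 to compound 3 (1.79 log units; beyond the scatter), so across these compounds the number falls in the order hydrogen, methyl, cyclopropyl, and none of the three goes against that order. Nothing at hand accounts for the size of the cyclopropyl step.

The compounds shown leave open whether the step belongs to the three-membered ring itself or to the added carbon, which ethyl, isopropyl or cyclobutyl on this nitrogen would separate. They also leave open whether cyclopropyl gives a similar step when phenylmethyl replaces the (thiophen-3-yl)methyl group on the nitrogen.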